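A few compounds are considered here, and "the series" means these few. Any claim that something is new, unique, unknown or untested is made for them only; others in the source may bear on it.

In a functional assay on LNCaP cells (Homo sapiens) for antiproliferative activity, read by propidium iodide staining, with a stated time of 96 h (a higher number here means a weaker inhibitor, a lower number a stronger inhibitor), compound 1 `CC(O)(CSc1ccc(F)cc1)C(=O)Nc1ccc(S(F)(F)(F)(F)F)cc1` gives 12500 nM, and compound 2 `CC(O)(COc1ccc(S(F)(F)(F)(F)F)cc1)C(=O)Nc1ccc(C#N)cc1C(F)(F)F` gives 12300 nM. These two numbers lie within the usual scatter of repeated measurements, so compound 2 stands level with compound 1 and the two cannot be ranked.

The next compound to consider is compound 3 `CC(O)(COc1ccc(S(F)(F)(F)(F)F)cc1)C(=O)Nc1ccc([N+](=O)[O-])cc1C(F)(F)F`. It keeps all of compound 2 except for one group: nitro in place of cyano on an aromatic carbon. The new group sits meta to a trifluoromethyl group and para to a large group. The change in full is nitro in place of cyano on an aromatic carbon.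

Within the data shown here, no two measured compounds here differ in just one place, so the data give no direct guide to the size of this swap. Among the measured compounds shown here, the best anchor is compound 2 at 12300 nM, the only measured compound that shares everything but this group with compound 3. No step beyond the scatter is expected in this assay, and neither direction is favoured. The expected change is small, a 1.1-fold lower number from compound 2 to compound 3 (0.05 log units; within the scatter). The estimated value for compound 3 is 11000 nM, with an expected range from 5000 nM to 24000 nM.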

Compound 3, half-maximal inhibitory concentration: 14800 nM
Estimate against measurement, compound 3: 1.3-fold (0.13 log units) below; measured number inside the range.
By their numbers in this assay, from the lowest: compounds 2, 1 and 3 (each within the scatter of the next).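

In this assay, putting nitro in place of cyano gives a 1.2-fold higher number from compound 2 to compound 3 (0.08 log units; within the scatter) and is the first change shown that touches a single place, so it offers the first direct reading of how much one group matters in this set. On the aromatic carbon meta to a trifluoromethyl group and para to a large group, these two groups cannot be told apart in this assay, even though nitro brings more heavy atoms and more hydrogen-bond acceptors than cyano. Nothing shown here explains why the two groups read alike.

Among these compounds, this one step covers only two groups at one position, so it cannot show whether this position tolerates change in general or whether these two simply happen to match. An amine, a carboxylic acid or a plain hydrogen on the same carbon could still move the number beyond the scatter, and the step leaves open whether nitro and cyano would also match with a different group in place of the trifluoromethyl group.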